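Thioether chain extension across two cores

The source may hold more compounds than are shown below. What is called first, only, known or untested is meant among the compounds shown, and "the series" means these compounds.

Compound 2 `CCCCCSc1nnc(COc2ccc3c(c2)CCC(=O)N3)o1` gives 10.2 mg/kg in a functional assay on the whole organism (strain Kunming) with Mus musculus as the target, with a stated time of 30 min; on this read-out higher numbers stand for an effect only at larger amounts of compound and lower numbers for an effect already at smaller amounts. Compound 1 `CCCCCCSc1nnc(COc2ccc3c(c2)CCC(=O)N3)o1` differs from it only by methyl in place of hydrogen on a saturated chain carbon, five bonds along the chain from a sulfur; in this assay compound 1 gives 17.9 mg/kg, and the step is a 1.8-fold higher number from compound 2 to compound 1 (0.24 log units; within the scatter). Compound 3 `CCCCCSc1nnc(COc2ccc(-n3cnnc3)cc2)o1` is built on a second core; the difference between the two cores is not broken down here. In this assay compound 3 gives 27.9 mg/kg, which against compound 2 lies beyond the scatter and against compound 1 within it. Compound 4 `CCCCCCSc1nnc(COc2ccc(-n3cnnc3)cc2)o1` carries the same change on the second core, namely (methyl in place of hydrogen on a saturated chain carbon, five bonds along the chain from a sulfur). The step from compound 3 to compound 4 is expected to be a 1.6-fold higher number from compound 3 to compound 4 (0.21 log units; within the scatter), which rests on the earlier step, a 1.8-fold higher number from compound 2 to compound 1 (0.24 log units; within the scatter), and on the value of compound 3. For compound 4 an estimated 45 mg/kg is expected, with a range from 22 mg/kg to 90 mg/kg.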

Compound 4, dose for half-maximal effect: 28.4 mg/kg
For compound 4 the middle estimate is 1.6-fold (0.20 log units) above the measured one; low and high end bracket the measured number.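

Methyl in place of hydrogen on a saturated chain carbon, five bonds along the chain from a sulfur, gives a 1.0-fold higher number from compound 3 to compound 4 (0.01 log units; within the scatter) in this assay on the core of compound 3. Each of the two steps is small enough to sit within the scatter, so the series shows no clear effect of this change on either core, and two pairs cannot establish how it would read on any further core. What can be said is that the step carried from one core to the other without a difference beyond the scatter: the same change on two cores in this assay, a 1.8-fold higher number (0.24 log units; within the scatter) from compound 2 to compound 1 and a 1.0-fold higher number (0.01 log units; within the scatter) from compound 3 to compound 4, 1.7-fold (0.24 log units) apart, within the scatter of two such steps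

Open, as far as these compounds go, is how a longer chain on the thioether would read on either core. Also open, from the compounds shown here alone, is whether a chain carrying an amine or a carboxylic acid would give a step that differs between the two cores.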